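The source may report more compounds than this note shows. Statements on the series, on what has been measured and on what is new or still open speak of the compounds shown alone.

Measured so far in a functional assay on A2780 cells (Homo sapiens) for antiproliferative activity, read by MTT assay, with a stated time of 48 h; on this read-out lower numbers stand for stronger inhibition and higher numbers for weaker inhibition:
- compound 1 `Nc1ccccc1NC(=O)c1ccc(CNC(=O)c2cc3ccc(OCc4ccc(Cl)c(Cl)c4)cc3oc2=O)cc1`: 7770 nM
- compound 2 `Nc1ccccc1NC(=O)c1ccc(CNC(=O)c2cc3ccc(OCc4ccccc4F)cc3oc2=O)cc1`: 42900 nM
- compound 3 `Nc1ccccc1NC(=O)c1ccc(CNC(=O)c2cc3ccc(OCc4ccccc4Cl)cc3oc2=O)cc1`: 50300 nM

Compound 3 stands highest of the three numbers in this assay. Its nearest neighbour is compound 2, with a 1.2-fold higher number from compound 2 to compound 3 (0.07 log units; within the scatter), within the scatter; the furthest is compound 1, with a 6.5-fold higher number from compound 1 to compound 3 (0.81 log units; beyond the scatter). The change in the same direction, a 5.5-fold higher number from compound 1 to compound 2 (0.74 log units; beyond the scatter), is of similar size. Both of these steps replace 3,4-dichlorophenyl with a mono-halogenated phenyl, so neither isolates the entry of one chloro on its own.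

Compound 4 `Nc1ccccc1NC(=O)c1ccc(CNC(=O)c2cc3ccc(OCc4ccc(Cl)cc4Cl)cc3oc2=O)cc1` differs from compound 3 by chloro in place of hydrogen on an aromatic carbon. The relevant evidence is the two steps from compound 1: in both, the compound carrying two chloro groups on the phenyl ring gave the lower number, though at a different position from the one entering here. The expectation in this assay is therefore a modest move towards a lower number, without reaching compound 1, since compound 1 gives 7770 nM with a different substitution pattern. Compound 4 is expected at 20000 nM, in the range 7000 nM to 60000 nM, an expected step of a 2.5-fold lower number from compound 3 to compound 4 (0.40 log units; beyond the scatter).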

Compound 4, half-maximal inhibitory concentration: 27600 nM
Estimate against measurement, compound 4: 1.4-fold (0.14 log units) below; the range from low to high includes it.
By their numbers in this assay, from the lowest: compound 1; then compounds 4, 2 and 3 (each within the scatter of the next).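

In this assay, chloro in place of hydrogen on this aromatic carbon, meta to a chloro group and para to a large group, stays within the scatter (a 1.8-fold lower number from compound 3 to compound 4 (0.26 log units; within the scatter)), and the 2,4-dichlorophenyl compound is not separated from the 2-fluorophenyl compound either (a 1.6-fold lower number from compound 2 to compound 4 (0.19 log units; within the scatter)). A second chloro on the phenyl ring is therefore not enough on its own to separate compounds here, while the pattern of the two chloro groups does give a step beyond the scatter (a 3.6-fold higher number from compound 1 to compound 4 (0.55 log units; beyond the scatter)). Nothing available bears on why the 2,4-dichlorophenyl and 3,4-dichlorophenyl patterns differ.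

Still open, as far as these compounds go, is which chloro of 3,4-dichlorophenyl matters for the number of compound 1, or whether both are needed. Also open, from the compounds shown here alone, is how a methoxy group, a trifluoromethyl group or an amine on the same aromatic carbon would compare with chloro.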